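Cyano for trifluoromethyl on two amide cores

The source may report more compounds than this note shows. Statements on the series, on what has been measured and on what is new or still open speak of the compounds shown alone.

Compound 2 `Cc1cc(C)c2sc(NC(=O)c3ccc(C(F)(F)F)cc3)nc2c1` gives 1.36 ug/mL in a functional assay on SK-HEP1 cells (Homo sapiens) for antiproliferative activity, read by sulforhodamine B assay; a higher number here means a weaker inhibitor of growth, a lower number a stronger inhibitor of growth. Compound 1 `Cc1cc(C)c2sc(NC(=O)c3ccc(C#N)cc3)nc2c1` carries the change cyano in place of trifluoromethyl on an aromatic carbon and gives 1.18 ug/mL in this assay, a step of a 1.2-fold lower number from compound 2 to compound 1 (0.06 log units; within the scatter). Compound 3 `COc1ccc2sc(NC(=O)c3ccc(C(F)(F)F)cc3)nc2c1` reaches only a limit in this assay, > 10 ug/mL; it sits at the limit of > 10 ug/mL in this assay, at which 1 of the 3 values shown sits. How the core of compound 3 differs from the core of compound 2 is not broken down here. Compound 4 `COc1ccc2sc(NC(=O)c3ccc(C#N)cc3)nc2c1` stands to compound 3 as compound 1 stands to compound 2, by the change (cyano in place of trifluoromethyl on an aromatic carbon), the same change at the same place. For compound 4 the expected step is a step that the limit leaves unreadable from compound 3 to compound 4, resting on the step of a 1.2-fold lower number from compound 2 to compound 1 (0.06 log units; within the scatter) seen for the measured pair. Compound 4 is therefore estimated at 12 ug/mL in this assay, with a real chance that only a limit is reported.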

Compound 4, concentration for 50% growth inhibition: > 10 ug/mL
Compound 4: only a limit was reported; the forecaster's own chance of this, stated with the estimate: 70%; the middle value lies beyond the limit too.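

Compound 3 and compound 4 both report only a limit, so no step between them can be read: the limit of > 10 ug/mL in this assay, at which 2 of the 4 values shown sit.

The compounds shown leave open whether cyano in place of trifluoromethyl changes growth inhibition on the core of compound 3.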